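The compounds below may be only part of what the source reports. "The series", "measured", "known", "first", "only" and "open" are said of these compounds alone.

Measured so far in an ADME assay on microsomes from liver (Homo sapiens) for metabolic stability, read by LC-MS, with NADPH named in the record, with a stated time of 60 min, tested at 1 uM, in the absence of a further agent; a lower number here means that less of the compound is left, a higher number that more of the compound is left:

compound 1 `COc1ccc(-c2scc3c(N4CC[C@@H](NC(C)=O)C4)nc(C)nc23)cc1OC`: > 95%
compound 2 `COc1ccc(-c2c(C)nc3c(N4CC[C@@H](NC(C)=O)C4)cc(C)nn23)cn1`: > 95%
compound 3 `COc1ccc(-c2c(C)nc3c(N4CC[C@@H](NC(=O)NC(C)C)C4)cc(C)nn23)cc1OC`: > 95%

Each of these readings is a limit of this assay rather than a number. Among the compounds with values here, for compound 1 the value > 95% says only that the reading reached the upper limit. For compound 2 the value > 95% is a limit of the same kind. For compound 3 the value > 95% is again a limit, so where compound 3 stands can be told only as far as that: it sits at the limit of > 95% in this assay, at which 3 of the 3 values shown sit, together with the two other measured compounds. Within the data shown here, with no finer numbers, no step between any two of the measured compounds can be sized; they show the same limit and nothing more.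

Compound 4 `COc1ccc(-c2c(C)nc3c(N4CC[C@@H](NS(=O)(=O)c5ccc(C#N)cc5)C4)cc(C)nn23)cc1OC` differs from compound 3 at one place: (4-cyanophenyl)sulfonyl in place of isopropylcarbamoyl on an amine nitrogen. The group that leaves is a small open chain with a hydrogen-bond donor; the group that enters is larger, carries a six-membered aromatic ring of carbon only and a nitrile, and has no hydrogen-bond donor.

Since all three measured values are limits, the expected change from compound 3 to compound 4 in this assay cannot be anchored to a measured step. The expectation is a downward step of a number at least 10 percentage points lower from compound 3 to compound 4 (that floor lies within the scatter), possibly beyond the scatter but with a fair chance that the reading again ends as a limit. Compound 4 is expected to give about 85%, with a range from 55% to 95%.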

Compound 4, percent of the compound remaining: > 95%
Compound 4 was reported as a limit; the forecaster's own chance of this, stated with the estimate: 45%; at least 10 percentage points between middle value and limit.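

In this assay compound 4 gives > 95%, which is a limit of the assay. Within the data shown here, compound 3 shows the same limit, so no step between compound 3 and compound 4 can be read. The compounds shown leave open how much more of each compound would remain, and whether they truly differ, since all the readings sit at one place: the limit of > 95% in this assay, at which 4 of the 4 values shown sit.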